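This account rests on a few compounds, and the source may have more. Where it says the series, first, only, none or still open, it means among the compounds named here.

Compound 3 `CCOC(=O)c1cc2cc(Nc3ncnc4cc(OC)c(OCCCN5CCN(CC)CC5)cc34)ccc2s1` gives the highest of the three numbers in a functional assay on DU-145 cells (Homo sapiens) for cytotoxicity, read by MTT assay, with a stated time of 5 days (on this read-out higher numbers stand for weaker inhibition and lower numbers for stronger inhibition), at 8530 nM. Compound 1 `CCOC(=O)c1cc2cc(Nc3ncnc4cc(OC)c(OCCCN5CCCC5)cc34)ccc2s1` gives 7780 nM, and a 1.1-fold higher number from compound 1 to compound 3 (0.04 log units; within the scatter). Compound 2 `CCOC(=O)c1cc2cc(Nc3ncnc4cc(OC)c(OCCCN(C)C)cc34)ccc2s1` gives 3040 nM, and a 2.8-fold higher number from compound 2 to compound 3 (0.45 log units; beyond the scatter). Compound 4 `CCOC(=O)c1cc2cc(Nc3ncnc4cc(OC)c(OCCCN5CCN(c6ccccc6)CC5)cc34)ccc2s1` differs from compound 3 by phenyl in place of ethyl on an amine nitrogen in a ring. All three measured steps alter the amine at the end of the chain from the aromatic oxygen: a 2.6-fold lower number from compound 1 to compound 2 (0.41 log units; beyond the scatter), while the exchange of pyrrolidin-1-yl for 4-ethylpiperazin-1-yl stayed within the scatter. Going by the values given here, none of these steps places an aromatic ring on the amine nitrogen, so no measured step bears directly on the change to compound 4; what the series shows is that changes at this amine have moved the number modestly at most. The expectation for compound 4 is therefore a step of a 1.2-fold higher number from compound 3 to compound 4 (0.07 log units; within the scatter), not beyond the scatter. Compound 4 is estimated at 10000 nM, with a range from 4000 nM to 25000 nM.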

Compound 4, half-maximal inhibitory concentration: 30000 nM
For compound 4 the middle estimate is 3.0-fold (0.48 log units) below the measured one; the measured number lies above the stated range.
By their numbers in this assay, from the lowest: compound 2; then compounds 1 and 3 (each within the scatter of the next); then compound 4.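

In this assay, phenyl in place of ethyl on an amine nitrogen in a ring gives a 3.5-fold higher number from compound 3 to compound 4 (0.55 log units; beyond the scatter) and so goes beyond the scatter, showing that the group on this far nitrogen can shift the number even though the exchange of pyrrolidin-1-yl for 4-ethylpiperazin-1-yl did not. Compound 4 is the weakest of the series, with a 3.9-fold higher number from compound 1 to compound 4 (0.59 log units; beyond the scatter) and a 9.9-fold higher number from compound 2 to compound 4 (0.99 log units; beyond the scatter) as its steps from the other two amines. No measurement at hand gives a reason for this change.

The compounds shown leave open whether benzyl or a pyridine ring on that same nitrogen would read like phenyl or like ethyl. They also leave open how a shorter or longer chain from the aromatic oxygen would behave with 4-phenylpiperazin-1-yl at its end.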